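Chloro for fluoro on a benzyl ring: expected no change

The source may hold more compounds than are shown below. What is called first, only, known or untested is meant among the compounds shown, and "the series" means these compounds.

Measured compounds:
- compound 1 `COc1cccc(Cc2cc(-c3ccc(Cl)cc3)nn(CC(=O)Nc3ccc(F)cc3)c2=O)c1`: > 50000 nM
- compound 2 `COc1cccc(Cc2cc(-c3ccc(F)cc3)nn(CC(=O)Nc3ccc(F)cc3)c2=O)c1`: > 50000 nM
- compound 3 `Cc1cc(Cc2cccc(F)c2)c(=O)n(CC(=O)Nc2ccc(Br)cc2)n1`: > 50000 nM

In a functional assay on HL-60 cells (Homo sapiens), read by calcium flux (a lower number here means that less compound is needed, a higher number that more compound is needed for the effect), compound 1 gives > 50000 nM, which is a limit of the assay and not a number. Compound 2 also gives only a limit in this assay, > 50000 nM. Compound 3 as well gives only a limit, > 50000 nM. All three values sit at the same boundary, as the evidence shows: the limit of > 50000 nM in this assay, at which 3 of the 3 values shown sit.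

Compound 2 and compound 1 differ by one change, (chloro in place of fluoro on an aromatic carbon), and the step that the two limits leave unreadable from compound 2 to compound 1 cannot be read because both sit at the limit (the limit of > 50000 nM in this assay, at which 3 of the 3 values shown sit).

Compound 4 `Cc1cc(Cc2cccc(Cl)c2)c(=O)n(CC(=O)Nc2ccc(Br)cc2)n1` has not yet been measured in this assay. It differs from compound 3 by chloro in place of fluoro on an aromatic carbon. Within the data shown here, this is the same kind of change as the one from compound 2 to compound 1, but the surroundings are not identical: in the measured pair the site is para to a large group, whereas in compound 3 to compound 4 it is meta to a large group. The cores of compound 3 and compound 2 differ as well, and that difference is not broken down here.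

Among the measured compounds shown here, compound 4 is expected to give a limit again in this assay, with the expected step that the limit leaves unreadable from compound 3 to compound 4 resting on the fact that compound 3 sits at the limit of > 50000 nM in this assay, at which 3 of the 3 values shown sit, and that no step between the three compounds has moved any of them off it. For compound 4 the estimate is therefore 60000 nM, within 20000 nM to 200000 nM.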

Compound 4, half-maximal effective concentration: > 50000 nM
Compound 4: a limit, no number (the forecaster's own chance of this, stated with the estimate: 85%); the middle value is on the limit's open side.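

In this assay compound 4 gives > 50000 nM, a limit of the assay and not a number. No step from compound 3 to compound 4 can be read, because both sit at the same boundary: the limit of > 50000 nM in this assay, at which 4 of the 4 values shown sit.

The compounds shown leave open whether chloro and fluoro differ at all in this assay, and which change to these structures, if any, would give a measurable value.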